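Methoxy on the pendant phenyl of a thiazolidinone series

The source may report more compounds than this note shows. Statements on the series, on what has been measured and on what is new or still open speak of the compounds shown alone.

The study concerns four compounds built on a thiazolidinone joined through an imine to a thiophene that carries an aryl group. Compound 1 is `COc1ccc(-c2cc(/N=C3/NC(=O)CS3)cs2)cc1` and compound 2 is `O=C1CS/C(=N\c2csc(-c3ccccc3)c2)N1`; compound 3 is `O=C1N/C(=N/c2csc(-c3ccc(Cl)cc3)c2)S/C1=C\c1ccccc1`, and the difference between its core and the core of compound 2 is not broken down here. Compound 4, `COc1ccc(/C=C2\S/C(=N\c3csc(-c4ccc(Cl)cc4)c3)NC2=O)cc1`, has not yet been measured.

In a functional assay on MCF7 cells (Homo sapiens) for cytotoxicity, read by MTT assay, with a stated time of 72 h (a lower number here means a stronger inhibitor, a higher number a weaker inhibitor), compound 1 gives > 50000 nM, which is a limit of the assay and not a number. In this assay compound 2 gives > 50000 nM, again a limit. Compound 3 gives > 50000 nM in this assay, also a limit. The change from compound 2 to compound 1 is methoxy in place of hydrogen on an aromatic carbon, and its size is a step that the two limits leave unreadable from compound 2 to compound 1, since both ends are limits. What the data do show is the limit of > 50000 nM in this assay, at which 3 of the 3 values shown sit.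

Among the compounds with values here, the change from compound 3 to compound 4 is methoxy in place of hydrogen on an aromatic carbon, the same change as the one from compound 2 to compound 1. With all three measured values sitting at a limit, the step from compound 3 to compound 4 is expected to be a step that the limit leaves unreadable from compound 3 to compound 4, resting on the unreadable step from compound 2 to compound 1 and on the position of compound 3 at > 50000 nM. Compound 4 is therefore estimated at 80000 nM in this assay, expected between 20000 nM and 400000 nM, most likely reported as a limit only.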

Compound 4, half-maximal inhibitory concentration: 1000 nM
The estimate for compound 4 lay 80-fold (1.90 log units) above the measured number; the measured number lies below the stated range.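

In this assay, within the data shown here, methoxy in place of hydrogen on an aromatic carbon, which here turns a phenyl into a 4-methoxyphenyl, gives an at least 50-fold lower number from compound 3 to compound 4 (1.69 log units; beyond the scatter), and this is the only readable step; it is a bound and not an exact size, as its starting point is a limit. This shows that the change can matter greatly on the core of compound 3, but not that it carries over from one core to another: the step between compound 2 and compound 1 cannot be read, and the phenyl that takes the methoxy in compound 4 is absent from both of those compounds, so the two steps do not touch the same ring. One readable step therefore sets up no rule across cores, and most of the series remains at a single limit: the limit of > 50000 nM in this assay, at which 3 of the 4 values shown sit.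

The compounds shown leave open whether an amine, a hydroxyl or a carboxylic acid in place of the methoxy on that same phenyl would also give a measurable number. They also leave open whether methoxy would give a step of this size without the chlorine on the other phenyl.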